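Bromo for methoxy on the fused core, second instance

The source may hold more compounds than are shown below. What is called first, only, known or untested is meant among the compounds shown, and "the series" means these compounds.

Compound 1 `COc1ccc2occ(C(=O)NC3CCN(Cc4ccccc4)CC3)c(=O)c2c1` gives 7.5% in an assay on isolated protein for inhibition of Amine oxidase [flavin-containing] A (Homo sapiens), read by fluorescence and Amplex Red, with stated times of 15 min and 20 min, tested at 100 uM; a lower number here means less inhibition, a higher number more inhibition at the concentration tested (going by the name of the read-out). Compound 2 `O=C(NC1CCN(Cc2ccccc2)CC1)c1coc2ccc(Br)cc2c1=O` gives 35.5% in this assay, and the change bromo in place of methoxy on an aromatic carbon made a step of a number 28 percentage points higher from compound 1 to compound 2 (beyond the scatter). Compound 3 `COc1ccc2c(=O)c(C(=O)NC3CCN(Cc4ccccc4)CC3)coc2c1` gives 37.4% in this assay; this value and that of compound 2 lie within the scatter of one another, and the difference between the core of compound 3 and the core of compound 1 is not broken down here. Compound 4 `O=C(NC1CCN(Cc2ccccc2)CC1)c1coc2cc(Br)ccc2c1=O` has not yet been measured. It differs from compound 3 by bromo in place of methoxy on an aromatic carbon, the same change as that from compound 1 to compound 2, at the same place. A step of a number 17.6 percentage points higher from compound 3 to compound 4 (beyond the scatter) is expected, smaller than the earlier step because compound 3 already starts from 37.4%. Compound 4 is estimated at 55%, with a range from 30% to 80%.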

Compound 4, a percentage reported as inhibition, at one concentration (the size of the read-out at that concentration, not a potency): 31.6%
Compound 4: the middle estimate sits 23.4 percentage points above what was measured; the measured number falls inside the stated range.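

In this assay, bromo in place of methoxy does not carry over from one core to the other with the same size of step: the same change on two cores in this assay, a number 28 percentage points higher (beyond the scatter) from compound 1 to compound 2 and a number 5.8 percentage points lower (within the scatter) from compound 3 to compound 4, 33.8 percentage points apart, beyond the scatter of two such steps. On the core of compound 3 the step is a number 5.8 percentage points lower from compound 3 to compound 4 (within the scatter), so the change has no effect there that can be told from the scatter. Two pairs do not explain why the cores differ, and a percentage at one concentration says nothing about potency.

As far as these compounds go, it remains open whether a chloro, a nitrile or an amine on the same aromatic carbon would also depend on the core. From the compounds shown here alone, it is equally open whether other changes would carry across the two cores.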